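Notes on compound 4 after three analogues at the limit

The source may hold more compounds than are shown below. What is called first, only, known or untested is meant among the compounds shown, and "the series" means these compounds.

Compound 1 `Cc1cc(N2CCNCC2)nc(SCc2nc3ccccc3[nH]2)n1` in a functional assay on MCF7 cells (Homo sapiens) for cytotoxicity, read by MTT assay, with a stated time of 72 h (on this read-out lower numbers stand for stronger inhibition and higher numbers for weaker inhibition), gives only a limit, > 100000 nM. Compound 2 `Cc1cc(NNC(N)=S)nc(SCc2nc3ccccc3[nH]2)n1` likewise reaches only the limit > 100000 nM in this assay. Compound 3 `COc1ccccc1Nc1cc(C)nc(SCc2nc3ccccc3[nH]2)n1` also stops at the limit > 100000 nM in this assay, so its standing among the three cannot be ranked. All values sit at the limit of > 100000 nM in this assay, at which 3 of the 3 values shown sit, and the steps a step that the two limits leave unreadable from compound 1 to compound 2, a step that the two limits leave unreadable from compound 1 to compound 3 and a step that the two limits leave unreadable from compound 2 to compound 3 therefore cannot be sized. Compound 4 `Cc1cc(N(C)Cc2ccccc2)nc(SCc2nc3ccccc3[nH]2)n1` differs from compound 3 by benzyl(methyl)amino in place of (2-methoxyphenyl)amino on an aromatic carbon. Going by the values given here, no measured step bears on this change in a readable way. With every neighbour at the limit, compound 4 is expected to stay near it, an estimated step that the limit leaves unreadable from compound 3 to compound 4. The estimate for compound 4 in this assay is 150000 nM, within 30000 nM to 1000000 nM.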

Compound 4, half-maximal inhibitory concentration: > 100000 nM
Compound 4 ended at the assay's limit; the forecaster's own chance of this, stated with the estimate: 75%; the middle value is on the limit's open side.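

Going by these compounds alone, no step from compound 1, compound 2 or compound 3 to compound 4 can be read in this assay: the limit of > 100000 nM in this assay, at which 4 of the 4 values shown sit. The compounds shown leave open how these four rank and whether any substituent on the shared core gives a measurable value.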